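The source may hold more compounds than are shown below. What is called first, only, known or untested is meant among the compounds shown, and "the series" means these compounds.

Notes on the series. Three members of one core share the same two hydroxyphenyl substituents and differ only in the group standing on the third aryl ring. Compound 1 `CC(C)(C)c1ccc(-n2nc(-c3ccc(C(F)(F)F)cc3O)nc2-c2ccccc2O)cc1` gives 81.1% in a functional assay on PC-12 cells (Rattus norvegicus) for cytotoxicity, read by MTT assay, with stated times of 2 h and 24 h, tested at 10 uM; a higher number here means a stronger effect of the compound at the concentration tested, a lower number a weaker effect. Compound 2 `Oc1cc(C(F)(F)F)ccc1-c1nc(-c2ccccc2O)n(-c2ccc(F)cc2)n1` gives 99.8% in that assay, and compound 3 `COc1ccc(-n2nc(-c3ccc(C(F)(F)F)cc3O)nc2-c2ccccc2O)cc1` gives 98.9%. Compound 3 therefore stands second highest of the three: its nearest neighbour is compound 2, within the scatter, and its furthest is compound 1, beyond the scatter, with a number 17.8 percentage points higher from compound 1 to compound 3 (beyond the scatter). The parallel step a number 18.7 percentage points higher from compound 1 to compound 2 (beyond the scatter) points the same way, whereas a number 0.9 percentage points lower from compound 2 to compound 3 (within the scatter) shows that the fluoro and methoxy members sit together.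

Compound 4 `N#Cc1ccc(-n2nc(-c3ccc(C(F)(F)F)cc3O)nc2-c2ccccc2O)cc1` is the next member, differing from compound 3 by cyano in place of methoxy on an aromatic carbon. Going by the values given here, no measured step exchanges a cyano group, so the guide is indirect: the two steps away from the tert-butyl member were modest, and the step between the two small groups lay within the scatter. Compound 3 already lies close to the ceiling of the read-out, leaving little room upward. On that basis compound 4 is expected to stay near compound 3, with an estimated a number 3.9 percentage points lower from compound 3 to compound 4 (within the scatter). The estimated value for compound 4 is 95%, with a range from 82% to 100%.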

Compound 4, a percentage reported as activity, at one concentration (the size of the read-out at that concentration, not a potency): 98.9%
The estimate for compound 4 lay 3.9 percentage points below the measured number; low and high end bracket the measured number.
By their numbers in this assay, from the lowest: compound 1; then compounds 3, 4 and 2 (each within the scatter of the next).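

A nitrile now joins the fluoro and methoxy members at this position, on an aromatic carbon para to a large group: in this assay, the exchange of 4-methoxyphenyl for 4-cyanophenyl gives no change at the digits printed from compound 3 to compound 4 (within the scatter), and the exchange of fluoro for cyano gives a number 0.9 percentage points lower from compound 2 to compound 4 (within the scatter), so this read-out does not separate these three groups. The tert-butyl member alone stands apart, with a number 17.8 percentage points higher from compound 1 to compound 4 (beyond the scatter), a step close in size to the two earlier steps away from compound 1, so the four compounds fall into one lower member, compound 1, and three that sit together. No measured evidence on these compounds bears on why the three groups match or why the tert-butyl member differs.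

The compounds shown leave open whether the separation is particular to tert-butyl or would recur with another group at this position, such as an amine, a carboxylic acid or a longer alkyl chain. Any difference among the three upper members also remains unresolved at this single concentration, and the contribution of the two hydroxyl groups and the trifluoromethyl group stays untested, as these are constant throughout.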